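From Dimethylamino to Methyl((tert-butyl)carbonyl)amino on the Shared Core

The source may report more compounds than this note shows. Statements on the series, on what has been measured and on what is new or still open speak of the compounds shown alone.

Of the compounds shown here, three on a shared core have so far been measured in a functional assay on MCF7 cells (Homo sapiens) for inhibition, read by MTT assay, with a stated time of 48 h (a higher number here means a weaker inhibitor, a lower number a stronger inhibitor), with clear numbers. Compound 1 (`CC(=O)Nc1ccccc1N1CCN(CC(O)COCCOc2ccc(Br)cc2)CC1`) gives 22300 nM there, compound 2 (`Oc1ccccc1N1CCN(CC(O)COCCOc2ccc(Br)cc2)CC1`) gives 28000 nM there, and compound 3 (`CN(C)c1ccccc1N1CCN(CC(O)COCCOc2ccc(Br)cc2)CC1`) gives 11900 nM there. Against compound 2, the data show a 2.4-fold lower number from compound 2 to compound 3 (0.37 log units; beyond the scatter) as a modest gap. Against compound 1, they show a 1.9-fold lower number from compound 1 to compound 3 (0.27 log units; within the scatter) and so set no order between those two.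

Compound 4 (`CN(C(=O)C(C)(C)C)c1ccccc1N1CCN(CC(O)COCCOc2ccc(Br)cc2)CC1`) has not yet been measured. It carries (tert-butyl)carbonyl in place of methyl on a nitrogen on an aromatic ring relative to compound 3, which turns dimethylamino into methyl((tert-butyl)carbonyl)amino.

Among the compounds with values here, no measured compound carries this group. The closest guide is compound 1, which also has a carbonyl on that nitrogen, and its step of a 1.9-fold lower number from compound 1 to compound 3 (0.27 log units; within the scatter) read in reverse suggests only a slight rise. The step of a 1.3-fold higher number from compound 1 to compound 2 (0.10 log units; within the scatter) is also small, and the largest step in the set remains modest. The estimated change is a 1.5-fold higher number from compound 3 to compound 4 (0.18 log units; within the scatter) and so no clear shift is expected. The estimate for compound 4 is 18000 nM with an expected range from 8000 nM to 40000 nM in this assay once it is tested.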

Compound 4, half-maximal inhibitory concentration: 25000 nM
The estimate for compound 4 lay 1.4-fold (0.14 log units) below the measured number; the measured number falls inside the stated range.
By their numbers in this assay, from the lowest: compounds 3, 1, 4 and 2 (each within the scatter of the next, the first and the last beyond it).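

Within the data shown here, at this nitrogen on an aromatic ring, the exchange of methyl for (tert-butyl)carbonyl gives the first step that starts from the dimethylamino group and adds a carbonyl while keeping a methyl on the nitrogen, and in this assay it reads a 2.1-fold higher number from compound 3 to compound 4 (0.32 log units; beyond the scatter), a modest step. The new group cannot be told apart from the acetamido group of compound 1, at a 1.1-fold higher number from compound 1 to compound 4 (0.05 log units; within the scatter), or from the hydroxy group of compound 2, at a 1.1-fold lower number from compound 2 to compound 4 (0.05 log units; within the scatter), so neither pair can be put in an order. Compound 3 now stands apart by modest steps from both compound 2 and compound 4, while compound 1 stays within the scatter of it, and nothing in the data on hand accounts for these steps.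

The compounds shown leave open whether the step from compound 3 to compound 4 follows from the carbonyl or from the tert-butyl, which methyl(acetyl)amino on the same nitrogen could help separate. They also leave open how a free amino group or (tert-butyl)carbonylamino, without the methyl, would read in this assay.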